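Benzimidazolyl for methoxyphenyl: expected solubility of compound 4

A few compounds are considered here, and "the series" means these few. Any claim that something is new, unique, unknown or untested is made for them only; others in the source may bear on it.

Compound 1 `CNC(=O)c1cc(C(=O)NC2CC2)cn(Cc2cccc(OC)c2)c1=O` gives 79 ug/mL. Compound 2 `CNC(=O)c1cc(C(=O)NC2CCC2)cn(Cc2ccccc2)c1=O` gives 28 ug/mL. Compound 3 `CNC(=O)c1cc(C(=O)NC2CCC2)cn(Cc2cccnc2)c1=O` reaches the limit >= 99 ug/mL.

Measured in a physicochemical assay for solubility (a higher number here means a more soluble compound, a lower number a less soluble compound), compound 1 holds the higher of the two numbers shown, compound 2 giving the lower one. The value of compound 3 is a limit of the assay, not a number, as is the limit of >= 99 ug/mL in this assay, at which 1 of the 3 values shown sits. The step to compound 4 `CNC(=O)c1cc(C(=O)NC2CC2)cn(Cc2ccc3nc[nH]c3c2)c1=O` is 1H-benzimidazol-6-yl in place of 3-methoxyphenyl on a saturated chain carbon bound to an aromatic nitrogen. For the measured compounds named here, the one measured step that bears on it is an at least 3.5-fold higher number from compound 2 to compound 3 (0.54 log units; beyond the scatter), where an aromatic ring with nitrogen entered at the same place. A rise at least as large is therefore expected in this assay, giving a 1.8-fold higher number from compound 1 to compound 4 (0.25 log units; within the scatter). Compound 4 is expected to give 140 ug/mL, within 55 ug/mL to 350 ug/mL.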

Compound 4, solubility: >= 163 ug/mL
Compound 4 gave a limit, no number; the forecaster's own chance of this, stated with the estimate: 55%; at least 1.1-fold (0.06 log units) between middle value and limit.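

In this assay, 1H-benzimidazol-6-yl in place of 3-methoxyphenyl gives an at least 2.0-fold higher number from compound 1 to compound 4 (0.31 log units; beyond the scatter), so a group with aromatic ring nitrogen at this place now raises the number on the core of compound 1 as well as on that of compound 2. This step starts from a compound that already held a higher number than compound 2. The value of compound 4, >= 163 ug/mL, is a limit and not a number: the limit of >= 163 ug/mL in this assay, at which 1 of the 4 values shown sits.

As far as these compounds go, how high compound 4 truly lies stays open, as does whether the rise follows the ring nitrogen or the hydrogen-bond donor. Also open, from the compounds shown here alone, is how a carboxylic acid or a dimethylamino group at this place would compare.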